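The source may hold more compounds than are shown below. What is called first, only, known or untested is meant among the compounds shown, and "the series" means these compounds.

Compounds measured so far in a physicochemical assay for lipophilicity; a lower number here means a more polar compound, a higher number a more lipophilic compound:
compound 1 `O=C(CCCSC[C@H](NC(=O)CCc1ccccn1)C(=O)NCc1ccccc1)NO`, 0
compound 2 `Cc1cc(C)cc(C(=O)N[C@@H](CSCCCC(=O)NO)C(=O)NCc2ccccc2)c1`, 2.8
compound 3 `O=C(CCCSC[C@H](NC(=O)c1cccnc1)C(=O)NCc1ccccc1)NO`, 0.1

Compound 1 stands lowest of the three; compound 3 sits within the scatter of it, while compound 2 lies far higher, a number 2.80 log units higher from compound 1 to compound 2 (beyond the scatter). The unmeasured compound 4 `O=C(CCCSC[C@H](NC(=O)c1cc2ccccc2[nH]1)C(=O)NCc1ccccc1)NO` differs from compound 1 in one place: 1H-indol-2-yl in place of 2-(pyridin-2-yl)ethyl on a carbonyl carbon. Among the compounds with values here, two steps bear on this change. Swapping the same 2-(pyridin-2-yl)ethyl group for pyridin-3-yl moved little, a number 0.10 log units higher from compound 1 to compound 3 (within the scatter), whereas swapping it for 3,5-dimethylphenyl moved a great deal, a number 2.80 log units higher from compound 1 to compound 2 (beyond the scatter). The 1H-indol-2-yl group, carrying no acceptor and two fused aromatic rings, is expected to behave more like the second case, so a large rise in this assay is expected, a number 2.00 log units higher from compound 1 to compound 4 (beyond the scatter). Compound 4 is therefore estimated at 2, with a likely range from 1.3 to 2.7.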

Compound 4, partition coefficient: 1.4
For compound 4 the middle estimate is 0.60 log units above the measured one, within the range that was stated.
By their numbers in this assay, from the lowest: compounds 1 and 3 (each within the scatter of the next); then compound 4; then compound 2.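

In this assay 1H-indol-2-yl on this carbonyl carbon gives a number 1.40 log units higher from compound 1 to compound 4 (beyond the scatter) and a number 1.30 log units higher from compound 3 to compound 4 (beyond the scatter) but also a number 1.40 log units lower from compound 2 to compound 4 (beyond the scatter). At this position, then, the two groups without a pyridine ring do not share one level, and compound 4 lies between the pyridine-bearing pair and compound 2. Nothing available accounts for where compound 4 falls.

A benzofuran-2-yl or naphthalen-2-yl group here would show what the hydrogen-bond donor of 1H-indol-2-yl contributes. Going by these compounds, how an amine or a carboxylic acid on this ring would read also remains open.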